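A few compounds are considered here, and "the series" means these few. Any claim that something is new, unique, unknown or untested is made for them only; others in the source may bear on it.

In a functional assay on HCT-116 cells (Homo sapiens) for antiproliferative activity, read by MTT assay, with a stated time of 72 h (a higher number here means a weaker inhibitor, a lower number a stronger inhibitor), compound 1 (`O=C(NO)c1ccc(NCCOc2ccc3cc2COC/C=C/COCc2cccc(c2)-c2ccnc(n2)N3)cc1`) gives 3200 nM and compound 2 (`O=C(NO)c1cccc(NCCOc2ccc3cc2COC/C=C/COCc2cccc(c2)-c2ccnc(n2)N3)c1`) gives 2010 nM. Among the measured compounds shown here, compound 1 therefore stands level with the only other measured compound, as the step between them, a 1.6-fold lower number from compound 1 to compound 2 (0.20 log units; within the scatter), shows. Compound 3 (`O=C(O)CCCCCCC(=O)Nc1ccc(NCCOc2ccc3cc2COC/C=C/COCc2cccc(c2)-c2ccnc(n2)N3)cc1`) keeps the core of compound 1 but carries ((6-carboxyhexyl)carbonyl)amino in place of hydroxycarbamoyl on an aromatic carbon, para to a large group: ((6-carboxyhexyl)carbonyl)amino in place of hydroxycarbamoyl on an aromatic carbon.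

For the measured compounds named here, the one measured step bears on this change only indirectly. It keeps the hydroxycarbamoyl group and alters only where that group sits, so it shows what a shift of place did in this assay, not what removing the group does. Going by the values given here, no measured compound lacks hydroxycarbamoyl, so the data hold no direct measure of this replacement. A modest move to a higher number in this assay is expected, although it may not clearly leave the scatter, and the uncertainty is wide. The expected change is a 1.9-fold higher number from compound 1 to compound 3 (0.27 log units; within the scatter). For compound 3 the estimated value is 6000 nM, with an expected range of 2000 nM to 18000 nM.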

Compound 3, half-maximal inhibitory concentration: 2700 nM
For compound 3 the middle estimate is 2.2-fold (0.35 log units) above the measured one; the measured number falls inside the stated range.
By their numbers in this assay, from the lowest: compounds 2, 3 and 1 (each within the scatter of the next).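

In this assay, putting ((6-carboxyhexyl)carbonyl)amino in place of hydroxycarbamoyl on the aromatic carbon gives a 1.2-fold lower number from compound 1 to compound 3 (0.07 log units; within the scatter) and, unlike the earlier pair, which only shifted hydroxycarbamoyl to another place, this pair measures the replacement of the group itself. For this pair, the larger entering group, with its longer chain and no hydroxycarbamoyl, leaves the read-out level with that of compound 1, so hydroxycarbamoyl is not required at this position to reach the level seen in this cell assay. No other measurement is available to account for this level result.

The compounds shown do not separate the contribution of the chain from that of its carboxylic acid, so a shorter chain ending in a carboxylic acid, or the same chain ending in a methyl ester or a primary amine, could each test which part of the group matters. They also leave open whether ((6-carboxyhexyl)carbonyl)amino would behave in the same way at the place that hydroxycarbamoyl occupies in compound 2, and whether a simple amine at this aromatic carbon would give a similar number.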